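Moving the nitro group from compound 2 to compound 3

The source may report more compounds than this note shows. Statements on the series, on what has been measured and on what is new or still open speak of the compounds shown alone.

In a functional assay on NCI-H460 cells (Homo sapiens) for cytotoxicity, read by sulforhodamine B assay (a higher number here means a weaker inhibitor of growth, a lower number a stronger inhibitor of growth), compound 1 `CC1=CC[C@@H]([C@@](C)(O)CCCC(C)(C)NC(=S)N/N=C\c2ccccc2[N+](=O)[O-])CC1` reads > 100000 nM as a limit of the assay, not a number. Among the measured compounds shown here, compound 2 `CC1=CC[C@@H]([C@@](C)(O)CCCC(C)(C)NC(=S)N/N=C\c2cccc([N+](=O)[O-])c2)CC1` reads 68600 nM and holds the only true number so far. For the measured compounds named here, the one measured step is an at least 1.4-fold lower number from compound 1 to compound 2 (0.16 log units; that floor lies within the scatter) and it bears on the next change as the only other nitrophenyl swap at this place. Compound 3 `CC1=CC[C@@H]([C@@](C)(O)CCCC(C)(C)NC(=S)N/N=C\c2ccc([N+](=O)[O-])cc2)CC1` carries 4-nitrophenyl in place of 3-nitrophenyl on a carbon with a double bond to nitrogen, with 4-nitrophenyl in place of 3-nitrophenyl on a carbon with a double bond to nitrogen as the counted difference. That single step gives no firm size or direction, so no step beyond the scatter is expected in this assay here. The expected step is a 1.1-fold lower number from compound 2 to compound 3 (0.06 log units; within the scatter) and stays small. Compound 3 is estimated at 60000 nM with an expected range from 25000 nM to 100000 nM in this series.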

Compound 3, concentration for total growth inhibition: > 100000 nM
Compound 3 ended at the assay's limit (the forecaster's own chance of this, stated with the estimate: 20%); middle value at least 1.6-fold (0.22 log units) from the limit.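

In this assay compound 3 gives > 100000 nM, a limit of the assay and not a number. Among the compounds shown here, putting 4-nitrophenyl in place of 3-nitrophenyl on a carbon with a double bond to nitrogen gives an at least 1.4-fold higher number from compound 2 to compound 3 (0.16 log units; that floor lies within the scatter), so compound 2 remains the only nitrophenyl compound here with a true number, although the floor of this step does not separate it from compound 3. The step between compound 1 and compound 3 cannot be read, and the three nitrophenyl placements cannot be put in a firm order: the limit of > 100000 nM in this assay, at which 2 of the 3 values shown sit.

From the compounds shown here alone, how far compound 1 and compound 3 lie past the limit stays open. Also open, going by these compounds, is whether an aminophenyl or carboxyphenyl group at this place would give a step beyond the scatter from compound 2.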